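A few compounds are considered here, and "the series" means these few. Any claim that something is new, unique, unknown or untested is made for them only; others in the source may bear on it.

Measured so far in a functional assay on A549 cells (Homo sapiens) for antiproliferative activity, read by MTT assay, with a stated time of 72 h; a higher number here means a weaker inhibitor, a lower number a stronger inhibitor:

compound 1 (`Cc1ccc(-c2noc(CCCCCCC(=O)NO)n2)cc1`): 5810 nM
compound 2 (`Nc1ccccc1NC(=O)CCCCCCc1nc(-c2ccccc2)no1`): 23900 nM

The higher of the two numbers belongs to compound 2 at 23900 nM and its gap to compound 1 lies beyond the scatter. These two compounds differ in more than one place, so the gap does not isolate any single change. Compound 3 (`Cc1ccc(-c2noc(CCCCCCC(=O)Nc3ccccc3N)n2)cc1`) departs from compound 2 by one change: methyl in place of hydrogen on an aromatic carbon (in words: methyl in place of hydrogen on an aromatic carbon, para to a large group). Within the data shown here, no measured pair shows this change alone, so the expectation in this assay is no step beyond the scatter, with at most a slight move toward a lower number. The estimated 1.2-fold lower number from compound 2 to compound 3 (0.08 log units; within the scatter) is accordingly small. Compound 3 is expected at 20000 nM (estimated range 8000 nM to 50000 nM).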

Compound 3, half-maximal inhibitory concentration: 9170 nM
Estimate against measurement, compound 3: 2.2-fold (0.34 log units) above; low and high end bracket the measured number.
By their numbers in this assay, from the lowest: compounds 1 and 3 (each within the scatter of the next); then compound 2.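

In this assay, among these compounds, phenyl to 4-methylphenyl gives the first step that changes one group on this ring: a 2.6-fold lower number from compound 2 to compound 3 (0.42 log units; beyond the scatter), modest but beyond the scatter, so a methyl on this aromatic carbon, para to a large group, does register in this read-out. With the 4-methylphenyl end held fixed, the other step, a 1.6-fold higher number from compound 1 to compound 3 (0.20 log units; within the scatter), stays within the scatter, so 2-aminophenyl in place of hydroxy on the amide-type nitrogen does not separate these two compounds here. Nothing shown gives a reason for either result.

Going by these compounds, the methyl step is read only with the 2-aminophenyl amide, so whether it carries over to the hydroxy end remains open. Also open, on these data alone, is whether methoxy, chlorine or trifluoromethyl at this carbon, or a longer chain, would move the number further.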